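A few compounds are considered here, and "the series" means these few. Any claim that something is new, unique, unknown or untested is made for them only; others in the source may bear on it.

Compound 2 `CC(C(=O)c1cc(C(F)(F)F)nn1-c1ccc2onc(N)c2c1)c1ccc(-c2ccccc2S(N)(=O)=O)cc1` reaches in an assay on isolated protein for inhibition of Trypsin (Homo sapiens) (a higher number here means a weaker inhibitor, a lower number a stronger inhibitor), only a limit, > 20000 nM. Compound 1 `CC(C(=O)c1cc(C(F)(F)F)nn1-c1ccc2onc(N)c2c1)c1ccc(-c2ccccc2S(C)(=O)=O)cc1F` gives in this assay likewise only a limit, > 20000 nM. Taken together this is the limit of > 20000 nM in this assay, at which 2 of the 2 values shown sit, so compound 2 cannot be placed any more precisely than that. Compound 3 `CC(C(=O)c1cc(C(F)(F)F)nn1-c1ccc2onc(N)c2c1)c1ccc(-c2ccccc2S(C)(=O)=O)cc1` carries methyl in place of amino on a sulfonyl sulfur, methyl in place of amino on a sulfonyl sulfur. Among the compounds with values here, no measured step covers this change. With compound 2 sitting only at a limit, the step from compound 2 to compound 3 in this assay is expected to be a step that the limit leaves unreadable from compound 2 to compound 3, none beyond the scatter, and most likely another limit. Compound 3 is therefore estimated at 30000 nM, within 10000 nM to 100000 nM.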

Compound 3, inhibition constant: > 20000 nM
Compound 3: no number, only a limit; the forecaster's own chance of this, stated with the estimate: 85%; the middle value lies beyond the limit too.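

Within the data shown here, compound 1, compound 2 and compound 3 all rest at a limit in this assay, so no step among them can be read: the limit of > 20000 nM in this assay, at which 3 of the 3 values shown sit. Going by these compounds, whether methyl for amino on a sulfonyl sulfur, or hydrogen for fluoro on an aromatic carbon, changes inhibition at all stays open.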